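Rearranged lactam isomer of a cytotoxic lactone

This account rests on a few compounds, and the source may have more. Where it says the series, first, only, none or still open, it means among the compounds named here.

Compound 1 `CC1=C(O)[C@@H](C/C(C)=C\CC[C@H](C)/C=C/C=C(\C)CCCc2ccoc2)OC1=O` gives 5.6 ug/mL in a functional assay on SK-MEL-2 cells (Homo sapiens) for cytotoxicity; on this read-out lower numbers stand for an effect already at smaller amounts and higher numbers for an effect only at larger amounts of compound.
Compound 2 `CC1=C(O)[C@H](C/C(C)=C\CC[C@H](C)/C=C/C=C(\C)CCCC2=CCN(CCC(C)C)C2=O)OC1=O` gives 4.1 ug/mL in this assay.
Compound 3 `CC1=C(O)[C@@H](C/C(C)=C\CC[C@H](C)/C=C/C=C(\C)CCCC2=CCN(CCC(C)C)C2=O)OC1=O` gives 3.4 ug/mL in this assay.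

Among these three numbers compound 2 holds the second highest; its nearest neighbour is compound 3 and the furthest is compound 1, both within the scatter. Compound 4 `CC1=C(O)[C@H](C/C(C)=C\CC[C@H](C)/C=C/C=C(\C)CCCC2=CC(=O)N(CCC(C)C)C2)OC1=O` has the same atoms as compound 2, joined differently: a group of 11 heavy atoms (9 carbon, 1 nitrogen, 1 oxygen; one five-membered non-aromatic ring with 1 hetero atom) in place of a group of 11 heavy atoms (9 carbon, 1 nitrogen, 1 oxygen; one five-membered non-aromatic ring with 1 hetero atom), on a saturated chain carbon, three bonds along the chain from a double-bonded chain carbon. Among the compounds with values here, two measured steps bear on this. Both a 1.6-fold lower number from compound 1 to compound 3 (0.22 log units; within the scatter) and a 1.2-fold lower number from compound 2 to compound 3 (0.08 log units; within the scatter) stay within the scatter, the latter because of the fact that compounds 2 and 3 differ only in the configuration as drawn. Neither a new side-chain ring nor a changed configuration moved the read-out, so no step beyond the scatter is expected in this assay. Compound 4 is therefore expected to give 4.1 ug/mL, with a range from 2 ug/mL to 8 ug/mL. The expected step is no change at the digits printed from compound 2 to compound 4 (within the scatter).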

Compound 4, concentration for half-maximal effect: 13.2 ug/mL
Compound 4: the middle estimate sits 3.2-fold (0.51 log units) below what was measured, outside the stated range (above it).
By their numbers in this assay, from the lowest: compounds 3, 2 and 1 (each within the scatter of the next); then compound 4.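

In this assay, within the data shown here, rejoining the same atoms in the group on this saturated chain carbon gives a 3.2-fold higher number from compound 2 to compound 4 (0.51 log units; beyond the scatter), the only step here beyond the scatter. Among these compounds, the group that leaves and the group that enters match in every computed count, so the read-out depends on how these atoms are joined, which the earlier steps did not show. Nothing given here accounts for this step.

Going by these compounds, it remains open whether the step persists with the configuration drawn in compound 3. Also open, on these data alone, is how an amine or a carboxylic acid at this place would read out.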